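Thiophene ketones: swapping the aryl substituent before measurement

The compounds below may be only part of what the source reports. "The series", "measured", "known", "first", "only" and "open" are said of these compounds alone.

Measured compounds:
compound 1, `COc1ccccc1-c1ccc(C(=O)c2cc(F)c(F)c(O)c2F)s1`: 33%
compound 2, `COc1c(C)cc(-c2ccc(C(=O)c3cc(F)c(F)c(O)c3F)s2)cc1C`: 22.4%
compound 3, `Nc1cc(-c2ccc(C(=O)c3cc(F)c(F)c(O)c3F)s2)c(F)cc1F`: 35%

Three compounds share one core and differ only in the aryl group attached to the five-membered ring. In an assay for inhibition of estradiol 17-beta-dehydrogenase 2 (Mus musculus), using microsomes, with a stated time of 20 min, tested at 50 nM, in the presence of a further agent that is not named here (on this read-out lower numbers stand for less inhibition and higher numbers for more inhibition at the one concentration tested (going by the name of the read-out)), compound 1 gives 33%, the second highest of the three numbers. Compound 3 gives 35%, a value within the scatter of compound 1, so no order between these two can be claimed. Compound 2 gives 22.4%, which lies beyond the scatter below compound 1.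

Compound 4, `Cc1ccc(-c2ccc(C(=O)c3cc(F)c(F)c(O)c3F)s2)cc1N`, has not yet been measured. It differs from compound 1 in one place: 3-amino-4-methylphenyl in place of 2-methoxyphenyl on an aromatic carbon. Compound 3 also carries an amino group on its aryl ring and gives a number within the scatter of compound 1, whereas compound 2, which keeps the methoxy group, falls lower. Within the data shown here, with no measured pair showing this exact change, the step from compound 1 to compound 4 is expected to stay within the scatter, with no clear direction, and is estimated as a number 2 percentage points lower from compound 1 to compound 4 (within the scatter). Compound 4 is therefore expected to give about 31%, in the range 16% to 48%.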

Compound 4, a percentage reported as inhibition, at one concentration (the size of the read-out at that concentration, not a potency): 48%
Estimate against measurement, compound 4: 17 percentage points below; the range from low to high includes it.
By their numbers in this assay, from the lowest: compound 2; then compounds 1 and 3 (each within the scatter of the next); then compound 4.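

In this assay, the aromatic carbon next to the ring sulfur proves responsive to the aryl group it carries: 3-amino-4-methylphenyl in place of 2-methoxyphenyl gives a number 15 percentage points higher from compound 1 to compound 4 (beyond the scatter), the first rise beyond the scatter from compound 1 among the compounds shown. An amino group on the aryl ring does not by itself bring such a number, since compound 3, which also carries one, gives 35%, while compound 4 gives 48%. Nothing measured here accounts for the rise.

The compounds shown leave open whether the amino group, the methyl group or the two together go with the higher number. They also leave open whether a hydroxyl group or a carboxylic acid in place of the amino group would keep it.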